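A few compounds are considered here, and "the series" means these few. Any claim that something is new, unique, unknown or untested is made for them only; others in the source may bear on it.

Compound 1 `CCN(CC)C(=O)CN(c1cccc(N(C)C)c1C#N)S(=O)(=O)c1ccc(OC)c(OC)c1`; compound 2 `CCN(CC)C(=O)CN(c1cc2c(C)nsc2cc1Cl)S(=O)(=O)c1ccc(OC)c(OC)c1`; compound 3 `CCN(CC)C(=O)CN(c1cc(C(C)C)ccc1Cl)S(=O)(=O)c1ccc(OC)c(OC)c1`.

In a functional assay on CHO cells for inhibition of Orexin/Hypocretin receptor type 1 (Homo sapiens), read by FLIPR and calcium flux (a higher number here means a weaker inhibitor, a lower number a stronger inhibitor), compound 2 gives 29 nM and compound 3 gives 888 nM. In this assay compound 1 sits at a limit rather than a number, > 10000 nM (the limit of > 10000 nM in this assay, at which 1 of the 3 values shown sits). Compound 3 thus stands highest of the two numbers shown, separated from compound 2 by a 31-fold higher number from compound 2 to compound 3 (1.49 log units; beyond the scatter). Compound 4 `CCN(CC)C(=O)CN(c1cc(N(C)C)ccc1C#N)S(=O)(=O)c1ccc(OC)c(OC)c1` has not been measured; it differs from compound 3 by 2-cyano-5-(dimethylamino)phenyl in place of 2-chloro-5-isopropylphenyl on a sulfonamide nitrogen. The step of an at least 11-fold lower number from compound 1 to compound 3 (1.05 log units; beyond the scatter) bears most on this, as it trades away the nitrile and dimethylamino group that compound 4 brings back, so a rise toward the limit is expected. For compound 4 the expected step is a 5.6-fold higher number from compound 3 to compound 4 (0.75 log units; beyond the scatter). Compound 4 is therefore estimated at 5000 nM, with a range from 1000 nM to 30000 nM.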

Compound 4, half-maximal inhibitory concentration: 166 nM
Beside the measured number, compound 4's estimate is 30-fold (1.48 log units) above it; the measured number lies below the stated range.
By their numbers in this assay, from the lowest: compound 2; then compound 4; then compound 3. At a limit, above all of these: compound 1.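

Placement on the ring matters: with 2-cyano-5-(dimethylamino)phenyl in place of 2-cyano-3-(dimethylamino)phenyl, the same two groups give an at least 60-fold lower number from compound 1 to compound 4 (1.77 log units; beyond the scatter). That step is a bound, as compound 1 stands at a limit and not at a number: the limit of > 10000 nM in this assay, at which 1 of the 4 values shown sits.

The nitrile and dimethylamino pair also outperforms the chloro and isopropyl pair, a 5.3-fold lower number from compound 3 to compound 4 (0.73 log units; beyond the scatter), yet falls short of the two-ring group, a 5.7-fold higher number from compound 2 to compound 4 (0.76 log units; beyond the scatter).

From the compounds shown here alone, the two groups changed together, so their separate shares remain open. A 2-cyano-5-methoxyphenyl or 2-chloro-5-(dimethylamino)phenyl group could begin to separate them.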